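A Methyl Added on a Saturated Ring Carbon

The source may hold more compounds than are shown below. What is called first, only, known or untested is meant among the compounds shown, and "the series" means these compounds.

Measured compounds in an ADME assay on liver for metabolic stability, with Liver microsome (Homo sapiens) as the target, read by LC-MS, using microsomes, with a stated time of 5 h; on this read-out lower numbers stand for slow clearance and higher numbers for fast clearance:
compound 1 `C[C@]1(O)C[C@](c2cccc(OC(F)(F)F)c2)([C@H](O)c2ccccn2)C1` gives 117 mL/min/kg
compound 2 `O[C@H](c1ccccn1)[C@]1(c2cccc(OC(F)(F)F)c2)C[C@H](O)C1` gives 150 mL/min/kg
compound 3 `O[C@H](c1ccccn1)[C@]1(c2ccnc(C(F)(F)F)c2)C[C@@H](O)C1` gives 83.3 mL/min/kg

Compound 2 and compound 1 differ by a single change, (methyl in place of hydrogen on a saturated ring carbon), and in this assay the result was a 1.3-fold lower number from compound 2 to compound 1 (0.11 log units; within the scatter). Compound 4 `C[C@]1(O)C[C@@](c2ccnc(C(F)(F)F)c2)([C@H](O)c2ccccn2)C1` is built from compound 3 by the same change, (methyl in place of hydrogen on a saturated ring carbon), at a place described in exactly the same words. Compound 3 and compound 2 have different cores, and the difference between the two cores is not broken down here. Because the earlier step of a 1.3-fold lower number from compound 2 to compound 1 (0.11 log units; within the scatter) stayed within the scatter, the step expected for compound 4 is a 1.2-fold lower number from compound 3 to compound 4 (0.08 log units; within the scatter). The estimate for compound 4 in this assay is 70 mL/min/kg, with a likely range from 40 mL/min/kg to 125 mL/min/kg.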

Compound 4, clearance: 66.7 mL/min/kg
For compound 4 the middle estimate is 1.0-fold (0.02 log units) above the measured one; measured number inside the range.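

In this assay, a methyl in place of hydrogen on a saturated ring carbon gave a 1.2-fold lower number from compound 3 to compound 4 (0.10 log units; within the scatter). Set beside the same change on the other core, the two steps agree: the same change on two cores in this assay, a 1.3-fold lower number (0.11 log units; within the scatter) from compound 2 to compound 1 and a 1.2-fold lower number (0.10 log units; within the scatter) from compound 3 to compound 4, 1.0-fold (0.01 log units) apart, within the scatter of two such steps So on these two cores the change carried over with no visible difference, but both steps are small enough to be lost in the scatter, so neither shows that the methyl has any real effect on clearance, and two cores say nothing firm about others.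

The compounds shown leave open whether a larger group on that same ring carbon, such as an ethyl chain or an amine, would give a step beyond the scatter. As far as these compounds go, how the methyl behaves on other cores also remains open.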